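Thiourea series: swapping the anilino halogen pattern

The source may hold more compounds than are shown below. What is called first, only, known or untested is meant among the compounds shown, and "the series" means these compounds.

Compound 2 `NS(=O)(=O)c1ccc(NC(=S)Nc2ccc3ncnc(Nc4ccc(F)c(Br)c4)c3c2)cc1` sits at 18200 nM in a functional assay on A-431 cells (Homo sapiens) for antiproliferative activity, read by MTT assay, with a stated time of 72 h (a lower number here means a stronger inhibitor, a higher number a weaker inhibitor), and its neighbour compound 1 `NS(=O)(=O)c1ccc(NC(=S)Nc2ccc3ncnc(Nc4ccc(Cl)c(C(F)(F)F)c4)c3c2)cc1` gives 18200 nM, so the two stand level. For the measured compounds named here, the one step measured so far, no change at the digits printed from compound 1 to compound 2 (within the scatter), moved nothing beyond the scatter. Compound 3 `NS(=O)(=O)c1ccc(NC(=S)Nc2ccc3ncnc(Nc4cccc(Cl)c4F)c3c2)cc1` carries a further exchange of the same kind: 3-chloro-2-fluorophenyl in place of 3-bromo-4-fluorophenyl on a nitrogen on an aromatic ring. Going by the values given here, since the only comparable step left this assay flat, the expected step of a 1.0-fold lower number from compound 2 to compound 3 (0.00 log units; within the scatter) is none beyond the scatter. For compound 3 the estimate is 18000 nM, with a range from 7000 nM to 45000 nM.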

Compound 3, half-maximal inhibitory concentration: 13100 nM
The estimate for compound 3 lay 1.4-fold (0.14 log units) above the measured number; low and high end bracket the measured number.
By their numbers in this assay, from the lowest: compounds 3, 1 and 2 (each within the scatter of the next).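

In this assay, a 1.4-fold lower number from compound 2 to compound 3 (0.14 log units; within the scatter), and a 1.4-fold lower number from compound 1 to compound 3 (0.14 log units; within the scatter). For the compounds shown here, a third halogen pattern on the nitrogen, 3-chloro-2-fluorophenyl, therefore stands level with both earlier groups, so this exchange, like the first, separates no compounds. No available evidence bears on why these values stand level.

All three groups are halogenated phenyl rings, which leaves open whether this flat reading extends beyond them. An unsubstituted phenyl, a phenyl bearing an amine or a carboxylic acid, or a longer alkyl chain on this nitrogen could still shift the number.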